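A Methyl to Ethyl Step at the Assay Limit

This account rests on a few compounds, and the source may have more. Where it says the series, first, only, none or still open, it means among the compounds named here.

In a functional assay on A549 cells (Homo sapiens) for cytotoxicity, read by MTT assay, with a stated time of 48 h (a lower number here means a stronger inhibitor, a higher number a weaker inhibitor), compound 1 (`NC(=O)CC[C@H](NS(=O)(=O)c1ccc([N+](=O)[O-])cc1)C(=O)O`) gives > 500000 nM, which is a limit. Compound 2 (`CNC(=O)CC[C@H](NS(=O)(=O)c1ccc([N+](=O)[O-])cc1)C(=O)O`) gives > 500000 nM, also a limit, so it has no exact number. Both compounds share one ceiling: the limit of > 500000 nM in this assay, at which 2 of the 2 values shown sit. Among the measured compounds shown here, the only measured step is a step that the two limits leave unreadable from compound 1 to compound 2, so it offers no size to carry forward. Compound 3 (`CCNC(=O)CC[C@H](NS(=O)(=O)c1ccc([N+](=O)[O-])cc1)C(=O)O`) differs from compound 2 by methyl in place of hydrogen on a saturated chain carbon bound to an amide-type nitrogen, turning methylcarbamoyl into ethylcarbamoyl. No shift beyond the scatter is expected in this assay, and another limit is the likeliest report. The expected change is a step that the limit leaves unreadable from compound 2 to compound 3. Compound 3 is estimated at 700000 nM, with an expected range from 300000 nM to 2000000 nM.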

Compound 3, half-maximal inhibitory concentration: 221000 nM
Beside the measured number, compound 3's estimate is 3.2-fold (0.50 log units) above it; the measured number lies below the stated range.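

In this assay, the ethylcarbamoyl group brings the only exact number among the compounds shown, with an at least 2.2-fold lower number from compound 2 to compound 3 (0.35 log units; beyond the scatter). Ethyl in place of the amide hydrogen gives an at least 2.2-fold lower number from compound 1 to compound 3 (0.35 log units; beyond the scatter), whereas the step from methylcarbamoyl cannot be read, so this added carbon on the chain is the first change with a visible effect. Both sizes are only minimums, because the true values of compound 1 and compound 2 remain unknown: the limit of > 500000 nM in this assay, at which 2 of the 3 values shown sit.

On these data alone, whether a longer chain such as propyl on the amide-type nitrogen lowers the number further remains open. So does the outcome with a phenyl ring there.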